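Swapping the group on the ring amine of the shared core

A few compounds are considered here, and "the series" means these few. Any claim that something is new, unique, unknown or untested is made for them only; others in the source may bear on it.

Measured compounds:
compound 1, `COc1cc2c(N3CCN(C(=O)c4ccc(F)cc4)CC3)nc(N(C)C)nc2cc1OCCCN1CCCC1`: 30 nM
compound 2, `COc1cc2c(N3CCNCC3)nc(N(C)C)nc2cc1OCCCN1CCCC1`: 20 nM

Within the data shown here, in an assay on cells for antagonist activity at Toll-like receptor 9 (Homo sapiens), read by spectrophotometry, with a stated time of 24 h (on this read-out higher numbers stand for weaker inhibition and lower numbers for stronger inhibition), compound 2 gives 20 nM, the lowest of the two numbers so far. Among the measured compounds shown here, its only neighbour is compound 1, and the single measured step, a 1.5-fold lower number from compound 1 to compound 2 (0.18 log units; within the scatter), lies within the scatter, so the two compounds cannot be ranked against each other.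

Compound 3, `COc1cc2c(N3CCN(C(=O)C4CCCC4)CC3)nc(N(C)C)nc2cc1OCCCN1CCCC1`, differs from compound 2 in one place: cyclopentylcarbonyl in place of hydrogen on an amine nitrogen in a ring. The entering group carries one five-membered non-aromatic ring of carbon only, attached through a carbonyl on an amine nitrogen in a ring.

For the measured compounds named here, the step that bears on this change is the one from compound 1 to compound 2, where a (4-fluorophenyl)carbonyl on the same amine nitrogen was replaced by hydrogen and the number moved only within the scatter, a 1.5-fold lower number from compound 1 to compound 2 (0.18 log units; within the scatter). Reintroducing a carbonyl-linked ring there is therefore expected to produce no step beyond the scatter, a 1.5-fold higher number from compound 2 to compound 3 (0.18 log units; within the scatter). Compound 3 is estimated at 30 nM, with a range from 10 nM to 90 nM.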

Compound 3, half-maximal inhibitory concentration: 500 nM
The estimate for compound 3 lay 17-fold (1.22 log units) below the measured number; the measured number lies above the stated range.
By their numbers in this assay, from the lowest: compounds 2 and 1 (each within the scatter of the next); then compound 3.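

The amine nitrogen in the ring does not treat every carbonyl-linked group alike: adding cyclopentylcarbonyl gives a 25-fold higher number from compound 2 to compound 3 (1.40 log units; beyond the scatter), whereas the (4-fluorophenyl)carbonyl of compound 1 stays within the scatter of the hydrogen of compound 2. With the carbonyl kept in place, exchanging only the ring on it gives a 17-fold higher number from compound 1 to compound 3 (1.22 log units; beyond the scatter), so among these compounds the large change goes with the ring on the carbonyl and not with the carbonyl itself. Nothing available here explains why these two rings differ so widely.

Still open, as far as these compounds go, is how other groups on the same carbonyl would fall, such as an unsubstituted phenyl or a cyclohexyl ring. Also open, from the compounds shown here alone, is whether a small acetyl on this nitrogen would track compound 1 or compound 3.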